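A few compounds are considered here, and "the series" means these few. Any claim that something is new, unique, unknown or untested is made for them only; others in the source may bear on it.

For the measured compounds named here, in a functional assay on MDA-MB-435 cells (Homo sapiens) (a lower number here means a stronger inhibitor of growth, a higher number a weaker inhibitor of growth), compound 1 (`COc1ccc(-c2cc(O)c3cccnc3n2)cc1`) gives 20000 nM and compound 2 (`Oc1cc(-c2ccc(Cl)cc2)nc2ncccc12`) gives 5890 nM, the lower of the two numbers so far. Compound 3 (`Cc1cnc2nc(-c3ccc(Cl)cc3)cc(O)c2c1`) has methyl in place of hydrogen on an aromatic carbon of the six-membered aromatic ring with 1 nitrogen, two atoms from the ring nitrogen: methyl in place of hydrogen on an aromatic carbon. Going by the values given here, the only measured step, a 3.4-fold lower number from compound 1 to compound 2 (0.53 log units; beyond the scatter), is modest, lies at a different place and involves no methyl, so it offers only a loose guide. Little change beyond the scatter is therefore expected, with a slight lean towards a lower number: a 1.3-fold lower number from compound 2 to compound 3 (0.12 log units; within the scatter). For compound 3 the estimated value is 4500 nM, within an expected range of 1500 nM to 13000 nM.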

Compound 3, concentration for 50% growth inhibition: 603 nM
Compound 3: the middle estimate sits 7.5-fold (0.87 log units) above what was measured; measured number outside the range, below it.
By their numbers in this assay, from the lowest: compound 3; then compound 2; then compound 1.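

Methyl in place of hydrogen on an aromatic carbon, two atoms from the ring nitrogen, gives a 9.8-fold lower number from compound 2 to compound 3 (0.99 log units; beyond the scatter) in this assay and so shows that this position of the shared core responds strongly to a single added carbon. For the compounds shown here, this step is larger than the one for chloro in place of methoxy, a 3.4-fold lower number from compound 1 to compound 2 (0.53 log units; beyond the scatter) and is the first sign of sensitivity on this ring. Nothing available explains the size of this step.

From the compounds shown here alone, whether the gain is particular to methyl remains open; an ethyl group, a chloro group or an amine on the same carbon would test this. Also open, going by these compounds, is whether methyl gives a similar step alongside the methoxy of compound 1.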